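This account rests on a few compounds, and the source may have more. Where it says the series, first, only, none or still open, it means among the compounds named here.

The study brings together three measured ureas and one that still awaits measurement. Compound 1 `CCc1cccc(NC(=O)N[C@H](C)c2ccccc2)c1`, compound 2 `C[C@@H](NC(=O)Nc1cccc(Cl)c1)c1ccccc1` and compound 3 `C[C@@H](NC(=O)Nc1cccc(I)c1)c1ccccc1` share one core and differ only in one group on an aromatic carbon. In an ADME assay on the whole organism with Oryza sativa as the target, tested at 10 uM (a lower number here means a stronger effect, a higher number a weaker effect of the compound at the concentration tested), compound 1 gives 36%. In this assay compound 2 gives 83%, the highest of the three numbers, and compound 3 gives 73%. The step of a number 47 percentage points higher from compound 1 to compound 2 (beyond the scatter) and the step of a number 37 percentage points higher from compound 1 to compound 3 (beyond the scatter) are both large, whereas the step of a number 10 percentage points lower from compound 2 to compound 3 (within the scatter) lies within the scatter, so compound 2 and compound 3 cannot be told apart on these data.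

Compound 4 `C[C@@H](NC(=O)Nc1ccc(Cl)c(Cl)c1)c1ccccc1` has not been measured. Its change from compound 2 is chloro in place of hydrogen on an aromatic carbon. Among the compounds with values here, no measured step replaces hydrogen with chloro; the measured steps exchange one group for another at a single aromatic carbon, and the two halogen-bearing compounds, compound 2 and compound 3, both sit high in the range. On that basis no step beyond the scatter is expected, and the step of a number 3 percentage points lower from compound 2 to compound 4 (within the scatter) is the estimate. Compound 4 is therefore expected to give about 80% in this assay, with a range from 55% to 98%.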

Compound 4, a percentage reported as activity, at one concentration (the size of the read-out at that concentration, not a potency): 93%
Beside the measured number, compound 4's estimate is 13 percentage points below it, within the range that was stated.
By their numbers in this assay, from the lowest: compound 1; then compounds 3, 2 and 4 (each within the scatter of the next, the first and the last beyond it).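

In this assay, within the data shown here, the step of a number 10 percentage points higher from compound 2 to compound 4 (within the scatter) is the only one here in which a group enters at an aromatic carbon that carried hydrogen, whereas the earlier steps exchanged one group for another at a single aromatic carbon. It shows that a chloro group on this carbon, ortho to a chloro group and para to a large group, can be added without a change beyond the scatter, so compound 2 and compound 4 cannot be told apart on these data. No measurement is available that bears on the reason for this result.

The compounds shown leave open whether a methoxy group, an amine or a carboxylic acid on this same aromatic carbon would also stay within the scatter of compound 2, or would produce a shift as large as the step of a number 47 percentage points higher from compound 1 to compound 2 (beyond the scatter). They also leave open whether chloro at this carbon would alter the number of compound 1, which carries ethyl in place of the first chloro group.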